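Swapping Pyridinyl for Phenyl on the Piperazine Ring

The compounds below may be only part of what the source reports. "The series", "measured", "known", "first", "only" and "open" are said of these compounds alone.

Among the measured compounds shown here, compound 2 `N#Cc1ccc(Nc2nc(Oc3ccnc4ccccc34)nc(N3CCN(c4ccccn4)CC3)n2)cc1C(F)(F)F` gives 85900 nM in a functional assay on DU-145 cells (Homo sapiens) for cytotoxicity, read by sulforhodamine B assay, with a stated time of 48 h (a lower number here means a stronger inhibitor of growth, a higher number a weaker inhibitor of growth), the highest of the two numbers so far. Compound 1 `N#Cc1ccc(Nc2nc(Oc3ccnc4ccccc34)nc(N3CCN(c4cccc(C(F)(F)F)c4)CC3)n2)cc1C(F)(F)F` gives 38700 nM, and a 2.2-fold higher number from compound 1 to compound 2 (0.35 log units; beyond the scatter). Compound 3 `N#Cc1ccc(Nc2nc(Oc3ccnc4ccccc34)nc(N3CCN(c4ccccc4)CC3)n2)cc1C(F)(F)F` takes the same step further: phenyl in place of pyridin-2-yl on an amine nitrogen in a ring. For the measured compounds named here, since the only step on this ring nitrogen, from compound 1 to compound 2, was modest and went upward, and compound 3 simply removes the ring nitrogen of compound 2, a small downward step is expected, about a 1.6-fold lower number from compound 2 to compound 3 (0.19 log units; within the scatter). Compound 3 is therefore estimated at 55000 nM, within 25000 nM to 120000 nM.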

Compound 3, concentration for 50% growth inhibition: > 100000 nM
Compound 3 ended at the assay's limit; the forecaster's own chance of this, stated with the estimate: 10%; middle value at least 1.8-fold (0.25 log units) from the limit.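

Compound 3 gives > 100000 nM in this assay, which is a limit of the assay and not a number. With phenyl on this ring nitrogen the result is an at least 1.1-fold higher number from compound 2 to compound 3 (0.06 log units; that floor lies within the scatter), so phenyl and pyridin-2-yl cannot be put in order here. Hydrogen in place of trifluoromethyl on an aromatic carbon gives an at least 2.5-fold higher number from compound 1 to compound 3 (0.41 log units; beyond the scatter), so in this pair trifluoromethyl goes with stronger growth inhibition.

Still open, as far as these compounds go, is whether a smaller group on that phenyl, such as a chlorine atom or a methoxy group, would do the same. Also open, from the compounds shown here alone, is whether a pyridin-2-yl carrying trifluoromethyl would match compound 1.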